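Series notes: benzoxazole sulfonamides, cytotoxicity in HEK293

The source may hold more compounds than are shown below. What is called first, only, known or untested is meant among the compounds shown, and "the series" means these compounds.

Measured compounds:
compound 1 `O=S(=O)(Nc1ccc(-c2nc3ccccc3o2)cc1)c1ccc(Cl)c(C(F)(F)F)c1`: 69000 nM
compound 2 `O=S(=O)(Nc1ccc(-c2nc3ccccc3o2)cc1)c1ccc(F)c(C(F)(F)F)c1`: 82000 nM

Among the measured compounds shown here, in an ADME assay on HEK293 cells (Homo sapiens) for cytotoxicity, read by resazurin assay, with a stated time of 48 h (a lower number here means that less compound is tolerated, a higher number that more compound is tolerated), compound 1 gives 69000 nM and holds the lowest of the two numbers so far; its nearest neighbour is compound 2, which in this assay gives 82000 nM. For the measured compounds named here, the only step between measured compounds, a 1.2-fold higher number from compound 1 to compound 2 (0.07 log units; within the scatter), swaps fluoro for chloro on an aromatic carbon and stays within the scatter.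

Compound 3 `O=[N+]([O-])c1cc(S(=O)(=O)Nc2ccc(-c3nc4ccccc4o3)cc2)ccc1Cl` is not yet measured. It differs from compound 1 by nitro in place of trifluoromethyl on an aromatic carbon. Going by the values given here, no measured step touches this change: the one step in hand concerns a halogen exchange and says nothing about a nitro group taking the place of a trifluoromethyl group. The two numbers in hand sit close together, and the shared core with its sulfonamide link is unchanged. With nothing to point either way, the step is expected to stay within the scatter, as a 1.2-fold lower number from compound 1 to compound 3 (0.06 log units; within the scatter). Compound 3 is therefore estimated at 60000 nM in this assay, with a range from 25000 nM to 150000 nM.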

Compound 3, half-maximal cytotoxic concentration: 85000 nM
For compound 3 the middle estimate is 1.4-fold (0.15 log units) below the measured one; the measured number falls inside the stated range.
By their numbers in this assay, from the lowest: compounds 1, 2 and 3 (each within the scatter of the next).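

In this assay, nitro in place of trifluoromethyl on the aromatic carbon ortho to a chloro group gives a 1.2-fold higher number from compound 1 to compound 3 (0.09 log units; within the scatter), so this step stays within the scatter even though the entering group has a different atom make-up and brings hydrogen-bond acceptors that the leaving group lacks. This is the first reading at this position: the halogen exchange from compound 1 to compound 2 left the trifluoromethyl group untouched, so the series so far has shown a change only at the chloro site. No accompanying data bear on why this exchange reads as it does.

From the compounds shown here alone, whether this position tolerates any group in this assay remains open, since an amine or a carboxylic acid in place of the trifluoromethyl group would test it with a group of another kind, and a single exchange cannot settle that. Also open, going by these compounds, are the effect of altering the sulfonamide link or the shared core, and whether nitro behaves the same way with fluoro in place of the chloro group.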